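From Allyl to Ethyl in Three Growth-Inhibiting Compounds

The source may report more compounds than this note shows. Statements on the series, on what has been measured and on what is new or still open speak of the compounds shown alone.

Measured compounds:
compound 1 `N#C[Se]c1ccc(NC(=O)OCc2ccc([N+](=O)[O-])cc2)cc1`: 11800 nM
compound 2 `C=CCOC(=O)Nc1ccc([Se]C#N)cc1`: 15000 nM
compound 3 `CCCCOC(=O)Nc1ccc([Se][Se]c2ccc(NC(=O)OCCCC)cc2)cc1`: 17300 nM

In a functional assay on MCF7 cells (Homo sapiens) for cytotoxicity, read by MTT assay, with a stated time of 72 h (a lower number here means a stronger inhibitor of growth, a higher number a weaker inhibitor of growth), compound 2 gives 15000 nM, the second highest of the three numbers, and both compound 3 and compound 1 lie within the usual scatter of it. Compound 4 `CCOC(=O)Nc1ccc([Se]C#N)cc1` differs from compound 2 by methyl in place of vinyl on a saturated chain carbon bound to an oxygen next to a carbonyl group. Within the data shown here, no step between two measured compounds differing in one place is available, so nothing here shows how such a change moves the number. Compound 4 is therefore expected to sit close to compound 2, with the step of no change at the digits printed from compound 2 to compound 4 (within the scatter) expected to stay within the scatter, in no particular direction. Compound 4 is estimated at 15000 nM, expected to fall between 7000 nM and 32000 nM.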

Compound 4, concentration for 50% growth inhibition: 8900 nM
Estimate against measurement, compound 4: 1.7-fold (0.23 log units) above; the range from low to high includes it.
By their numbers in this assay, from the lowest: compounds 4, 1, 2 and 3 (each within the scatter of the next).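

Among these compounds, the change from allyl to ethyl in this assay gives a 1.7-fold lower number from compound 2 to compound 4 (0.23 log units; within the scatter) and is the first direct reading at this position. It shows that the double bond can be replaced, with the chain one carbon shorter, without the number moving beyond the usual scatter of repeated measurements. No measurement at hand offers an explanation for this step. On these data alone, whether a longer chain or a chain carrying an amine would move the number beyond the scatter stays open. A single step also cannot show whether this change would behave alike on another core.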